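A Second Fluorine on the Amide Phenyl Ring

This account rests on a few compounds, and the source may have more. Where it says the series, first, only, none or still open, it means among the compounds named here.

Compound 1 `Cc1nc(C(NC(=O)C(=O)Nc2ccc(F)c(F)c2)C2CCCCN2)sc1CO`, compound 2 `Cc1nc(C(NC(=O)C(=O)Nc2ccc(F)cc2)C2CCCCN2)sc1CO` and compound 3 `Cc1nc(C(NC(=O)C(=O)Nc2ccc(F)cc2)C2CCCCN2)sc1CCO` were tested in an ADME assay on MT2 cells (Homo sapiens) for cytotoxicity, read by XTT assay, with a stated time of 4 days; a lower number here means that less compound is tolerated, a higher number that more compound is tolerated. For compound 1 the assay reports only a limit, > 87000 nM. For compound 2 it also reports only a limit, > 113000 nM. Compound 3 gives a number, 109000 nM. The change from compound 2 to compound 1 is fluoro in place of hydrogen on an aromatic carbon, and its step in this assay is a step that the two limits leave unreadable from compound 2 to compound 1. The cores of compound 2 and compound 3 differ by hydroxymethyl in place of hydroxy on a saturated chain carbon bound to an aromatic carbon, with a step of an at least 1.0-fold lower number from compound 2 to compound 3 (0.01 log units; that floor lies within the scatter). Among the compounds with values here, compound 4 `Cc1nc(C(NC(=O)C(=O)Nc2ccc(F)cc2F)C2CCCCN2)sc1CCO` is not yet measured; it differs from compound 3 by fluoro in place of hydrogen on an aromatic carbon, the same kind of change as the one to compound 1, though here the place is ortho to a large group and meta to a fluoro group rather than ortho to a fluoro group and meta to a large group. Because the step that the two limits leave unreadable from compound 2 to compound 1 is unreadable from two limits, the expectation for compound 4 rests mainly on compound 3 at 109000 nM, and the expected step is a 1.1-fold lower number from compound 3 to compound 4 (0.04 log units; within the scatter). Compound 4 is estimated at 100000 nM, between 50000 nM and 200000 nM.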

Compound 4, half-maximal cytotoxic concentration: > 105000 nM
Compound 4: no number, only a limit (the forecaster's own chance of this, stated with the estimate: 40%); at least 1.0-fold (0.02 log units) between middle value and limit.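

Compound 4 gives only a limit, not a number, and the step from compound 3 to compound 4 cannot be read. As far as these compounds go, whether a second fluoro on the 4-fluorophenyl group changes the tolerated concentration in this assay stays open: compound 1 and compound 4 both give only limits.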